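Methoxycarbonyl to methoxy: what compound 4 may show

This account rests on a few compounds, and the source may have more. Where it says the series, first, only, none or still open, it means among the compounds named here.

Measured in an ADME assay on HT-29 cells (Homo sapiens) for cytotoxicity, read by MTT assay, with a stated time of 72 h; on this read-out higher numbers stand for weaker inhibition and lower numbers for stronger inhibition:
- compound 1 `COc1ccc(C2=C(c3cc(OC)c(OC)c(OC)c3)C(=O)CC2O[SiH2]C(C)(C)C)cc1`: > 100 ug/mL (a limit)
- compound 2 `COc1ccc(OC)c(C2=C(c3cc(OC)c(OC)c(OC)c3)C(=O)CC2O[SiH2]C(C)(C)C)c1`: 5 ug/mL
- compound 3 `COC(=O)c1cc(C2=C(c3cc(OC)c(OC)c(OC)c3)C(=O)CC2O[SiH2]C(C)(C)C)ccc1OC`: > 100 ug/mL (a limit)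

Compound 3 stands at the limit of > 100 ug/mL in this assay, at which 2 of the 3 values shown sit, so it has a limit and no number. Compound 4 `COc1ccc(C2=C(c3cc(OC)c(OC)c(OC)c3)C(=O)CC2O[SiH2]C(C)(C)C)cc1OC` differs from it as follows: methoxy in place of methoxycarbonyl on an aromatic carbon. Two large steps bear on this, an at least 20-fold higher number from compound 2 to compound 3 (1.30 log units; beyond the scatter) and an at least 20-fold lower number from compound 1 to compound 2 (1.30 log units; beyond the scatter), both beyond the scatter and both changing the same aryl group. The third is a step that the two limits leave unreadable from compound 1 to compound 3. A large drop is possible, but it is not assured. The expected change is an at least 3.3-fold lower number from compound 3 to compound 4 (0.52 log units; beyond the scatter), towards a lower number. For compound 4 the estimated value is 30 ug/mL, with an expected range of 5 ug/mL to 100 ug/mL.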

Compound 4, half-maximal inhibitory concentration: > 100 ug/mL
Compound 4: no number, only a limit (the forecaster's own chance of this, stated with the estimate: 40%); middle value at least 3.3-fold (0.52 log units) from the limit.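

In this assay compound 4 gives only a limit, > 100 ug/mL, so methoxy in place of methoxycarbonyl at this place, ortho to a methoxy group, yields no measurable value. The steps to compound 4 from compound 3 and from compound 1 cannot be read, as both ends of each are limits. Having 3,4-dimethoxyphenyl in place of 2,5-dimethoxyphenyl gives an at least 20-fold higher number from compound 2 to compound 4 (1.30 log units; beyond the scatter), so the placing of the two methoxy groups separates this pair.

Going by these compounds, how the compounds at the limit rank among themselves stays open: the limit of > 100 ug/mL in this assay, at which 3 of the 4 values shown sit. Whether an amine or a carboxylic acid at this place would give a measurable value also stays open.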